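Series notes ahead of the measurement of compound 3

The compounds below may be only part of what the source reports. "The series", "measured", "known", "first", "only" and "open" are said of these compounds alone.

compound 1 `COc1cccc(/C=C/C(=O)c2sc(Nc3cccc(C)c3)nc2C)c1` — > 25000 nM
compound 2 `COc1cccc(/C=C/C(=O)c2sc(Nc3ccc(Cl)cc3)nc2C)c1` — > 25000 nM

Compound 1 and compound 2 share one core and differ only in the phenyl group on a nitrogen on an aromatic ring. In a functional assay on BGC-823 cells (Homo sapiens) for cytotoxicity, read by MTT assay (on this read-out lower numbers stand for stronger inhibition and higher numbers for weaker inhibition), compound 1 gives > 25000 nM, which is a limit of the assay rather than a number. In this assay compound 2 gives > 25000 nM, likewise a limit of the assay. The step that the two limits leave unreadable from compound 1 to compound 2 therefore cannot be read, because of the limit of > 25000 nM in this assay, at which 2 of the 2 values shown sit. Compound 2 thus stands at the limit, and the numbers shown give no finer position for it.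

Compound 3 `Cc1nc(Nc2ccc(Cl)cc2)sc1C(=O)/C=C/c1ccc(Cl)cc1` is the next member. It differs from compound 2 by 4-chlorophenyl in place of 3-methoxyphenyl on a double-bonded chain carbon bound to a double-bonded chain carbon. Within the data shown here, no measured step touches this position: the only recorded step concerns the phenyl group on a nitrogen on an aromatic ring and is itself unreadable, so nothing measured shows whether the group on a double-bonded chain carbon moves this assay. The expectation is that compound 3 will most likely also sit at the limit, with a step that the limit leaves unreadable from compound 2 to compound 3 as the expected step. Compound 3 is estimated at 30000 nM, within 8000 nM to 120000 nM.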

Compound 3, half-maximal inhibitory concentration: > 25000 nM
Compound 3 ended at the assay's limit; the forecaster's own chance of this, stated with the estimate: 70%; the middle value lies beyond the limit too.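

In this assay no new step can be read between compound 2 and compound 3, because both values are limits of the assay and not numbers: the limit of > 25000 nM in this assay, at which 3 of the 3 values shown sit. The compounds shown leave open whether either phenyl group moves this read-out at all, and where any of the three compounds lies beyond the limit.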